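The compounds below may be only part of what the source reports. "The series", "measured", "known", "first", "only" and "open" are said of these compounds alone.

Compound 3 `C=CC(=O)N1C(=O)CC(c2ccccc2Cl)Sc2ccccc21` gives 33800 nM in a functional assay on NB-4 cells (Homo sapiens) for cytotoxicity, read by CCK-8 assay, with a stated time of 24 h (on this read-out higher numbers stand for weaker inhibition and lower numbers for stronger inhibition), the middle of three numbers that all lie within the usual scatter of one another: compound 2 `C=CC(=O)N1C(=O)CC(c2cccc(Cl)c2)Sc2ccccc21` gives 31700 nM and compound 1 `C=CC(=O)N1C(=O)CC(c2ccc(C)cc2)Sc2ccccc21` gives 37300 nM. The steps of a 1.2-fold lower number from compound 1 to compound 2 (0.07 log units; within the scatter), a 1.1-fold lower number from compound 1 to compound 3 (0.04 log units; within the scatter) and a 1.1-fold higher number from compound 2 to compound 3 (0.03 log units; within the scatter) show that moving or exchanging the substituent on this aryl group leaves this assay essentially unmoved. Compound 4 `C=CC(=O)N1C(=O)CC(c2ccccc2)Sc2ccccc21` differs from compound 3 by hydrogen in place of chloro on an aromatic carbon. Among the measured compounds shown here, no measured step removes the substituent altogether, so the three small steps are the only guide, and the author expects none beyond the scatter, a step of a 1.1-fold higher number from compound 3 to compound 4 (0.03 log units; within the scatter). Compound 4 is therefore estimated at 36000 nM, with a range from 15000 nM to 85000 nM.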

Compound 4, half-maximal inhibitory concentration: 35500 nM
Beside the measured number, compound 4's estimate is 1.0-fold (0.01 log units) above it; low and high end bracket the measured number.
By their numbers in this assay, from the lowest: compounds 2, 3, 4 and 1 (each within the scatter of the next).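

Taking the substituent off altogether, which no earlier step did, leaves this assay unmoved: hydrogen in place of chloro gives a 1.1-fold higher number from compound 3 to compound 4 (0.02 log units; within the scatter) and a 1.1-fold higher number from compound 2 to compound 4 (0.05 log units; within the scatter) while hydrogen in place of methyl gives a 1.1-fold lower number from compound 1 to compound 4 (0.02 log units; within the scatter) and all three lie within the scatter. Among these four compounds, then, the plain phenyl group stands level with the substituted aryl groups. No evidence at hand explains this flat result.

As far as these compounds go, whether an amine or a carboxylic acid on this aryl group would shift the number remains open. So does the effect of exchanging the acryloyl group on the shared core for a propanoyl group.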